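A few compounds are considered here, and "the series" means these few. Any claim that something is new, unique, unknown or untested is made for them only; others in the source may bear on it.

Of the compounds shown here, three that share one core have been measured in a functional assay on PC-3 cells (Homo sapiens) for cytotoxicity, read by MTT assay, with a stated time of 72 h; a higher number here means a weaker inhibitor, a lower number a stronger inhibitor. Compound 1 `FC(F)(F)c1ccc(CSc2nc(Nc3ccccc3C(F)(F)F)c3ccccc3n2)cc1` gives 34800 nM. Compound 2 `Cc1ccccc1Nc1nc(SCc2ccc(C(F)(F)F)cc2)nc2ccccc12` gives 36900 nM. Compound 3 `FC(F)(F)c1ccc(CSc2nc(Nc3cccc(Br)c3)c3ccccc3n2)cc1` gives 8680 nM, the lowest of the three numbers. The change from compound 1 to compound 2, methyl in place of trifluoromethyl on an aromatic carbon, gave a 1.1-fold higher number from compound 1 to compound 2 (0.03 log units; within the scatter). Putting 3-bromophenyl on the nitrogen in place of 2-(trifluoromethyl)phenyl gave a 4.0-fold lower number from compound 1 to compound 3 (0.60 log units; beyond the scatter), and in place of 2-methylphenyl gave a 4.3-fold lower number from compound 2 to compound 3 (0.63 log units; beyond the scatter).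

Compound 4 `Cc1ccc(Nc2nc(SCc3ccc(C(F)(F)F)cc3)nc3ccccc23)cc1` is not yet measured. It differs from compound 3 in one place: 4-methylphenyl in place of 3-bromophenyl on a nitrogen on an aromatic ring. The two measured steps that bear on this are the exchanges on the same nitrogen, each modest, and each ran toward 3-bromophenyl, which is now being removed. The steps give no direct reading for 4-methylphenyl, so a modest rise in the number is the likeliest outcome, with a wide range. Compound 4 is therefore expected at about 20000 nM in this assay, between 6000 nM and 60000 nM. The expected step is a 2.3-fold higher number from compound 3 to compound 4 (0.36 log units; beyond the scatter).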

Compound 4, half-maximal inhibitory concentration: 21100 nM
Beside the measured number, compound 4's estimate is 1.1-fold (0.02 log units) below it; measured number inside the range.
By their numbers in this assay, from the lowest: compound 3; then compounds 4, 1 and 2 (each within the scatter of the next).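

In this assay, among these compounds, the exchange of 3-bromophenyl for 4-methylphenyl on the nitrogen raises the number (a 2.4-fold higher number from compound 3 to compound 4 (0.39 log units; beyond the scatter)), so 3-bromophenyl remains the only group on this nitrogen with steps to all the others beyond the scatter. The other two exchanges stay within the scatter: 2-methylphenyl to 4-methylphenyl (a 1.7-fold lower number from compound 2 to compound 4 (0.24 log units; within the scatter)) and 2-(trifluoromethyl)phenyl to 4-methylphenyl (a 1.6-fold lower number from compound 1 to compound 4 (0.22 log units; within the scatter)). Moving the methyl around the ring therefore gives no readable change, and 4-methylphenyl does not separate from the two groups already tested.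

Going by these compounds, the bromine and its place on the ring differ together, so these compounds cannot show which of the two matters, and how a chlorine, a methoxy group or an amine on this ring would read remains open. Nothing available explains why 3-bromophenyl stands apart.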